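This account rests on a few compounds, and the source may have more. Where it says the series, first, only, none or still open, it means among the compounds named here.

In a functional assay on the whole organism for inhibition, with Brassica rapa subsp. chinensis as the target, with a stated time of 3 days, tested at 100 ppm (a higher number here means more inhibition of growth at the concentration tested, a lower number less inhibition of growth), compound 1 `CCCCCCCCCCCCCCCCNC(=O)/C=C/c1ccccc1` gives 20%. Compound 2 `C=CCc1ccc(OC(=O)/C=C/c2ccc(C(C)C)cc2)c(OC)c1` gives 40% in this assay, a number that stands beyond the scatter above the value of compound 1, while compound 3 `O=C(/C=C/c1ccc(Cl)cc1)OCCOc1ccccc1` gives 30%, which lies within the scatter of the value of compound 1. Compound 4 `CCCCCCCCCCCCNC(=O)/C=C/c1ccccc1` differs from compound 1 by hydrogen in place of butyl on a saturated chain carbon, ten or more bonds along the chain from an amide-type nitrogen; the same difference, cut one bond further out, reads pentyl to methyl, hexyl to ethyl, heptyl to propyl. For the measured compounds named here, no measured pair shows a change of this kind, so there is no step to lean on. The expected step of no change at the digits printed from compound 1 to compound 4 (within the scatter) is none beyond the scatter in this assay. Compound 4 is thus expected to give 20%, with a range from 5% to 40%.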

Compound 4, percent growth inhibition at one concentration: 48%
Beside the measured number, compound 4's estimate is 28 percentage points below it, and the stated range ends below it.
By their numbers in this assay, from the lowest: compounds 1, 3, 2 and 4 (each within the scatter of the next, the first and the last beyond it).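

In this assay, hydrogen in place of butyl on a saturated chain carbon, ten or more bonds along the chain from an amide-type nitrogen, gives a number 28 percentage points higher from compound 1 to compound 4 (beyond the scatter). For the compounds shown here, this shows that the outer part of the chain is not indifferent in this test, as the opening estimate had assumed, and it is the first step read at this place. Nothing at hand explains the step. The compounds shown leave open whether a still shorter chain would continue in this direction, since one pair marks no trend. They also leave open how a terminal amine or a carboxylic acid on the chain would read.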